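This account rests on a few compounds, and the source may have more. Where it says the series, first, only, none or still open, it means among the compounds named here.

Among the compounds with values here, compound 2, with the structure `COC(=O)[C@@]1(C)CC[C@@H]2C3=C1CC[C@@H](C)[C@]3(C)C[C@@H]1c3cccc(C)c3N[C@H]21`, is one of two compounds measured in a functional assay on WiDr cells (Homo sapiens) for inhibition, read by sulforhodamine B assay, with a stated time of 48 h; on this read-out higher numbers stand for weaker inhibition of growth and lower numbers for stronger inhibition of growth; compound 1, with the structure `COC(=O)[C@@]1(C)CCC=C2[C@@H]1CC[C@@H](C)[C@]2(C)Cc1c(C)[nH]c2c(Cl)cccc12`, is the other. In this assay compound 1 gives 29000 nM, and in this assay compound 2 gives 43000 nM. The two numbers lie within the usual scatter of each other, so neither can be placed ahead of the other; compound 2 simply stands as the starting point for the step that follows, both compounds being weak inhibitors of growth on this read-out. Compound 3, with the structure `COC(=O)[C@@]1(C)CC[C@@H]2C3=C1CC[C@@H](C)[C@]3(C)C[C@@H]1c3cccc(Cl)c3N[C@H]21`, shares its core with compound 2 and differs by chloro in place of methyl on an aromatic carbon. Within the data shown here, no measured pair here isolates that exchange, and the data give no ground to expect a step beyond the scatter in either direction. Compound 3 is therefore expected to give about 35000 nM, within 12000 nM to 100000 nM, which would mean an expected step from compound 2 to compound 3 of a 1.2-fold lower number from compound 2 to compound 3 (0.09 log units; within the scatter).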

Compound 3, concentration for 50% growth inhibition: 67000 nM
Compound 3: the middle estimate sits 1.9-fold (0.28 log units) below what was measured; the measured number falls inside the stated range.
By their numbers in this assay, from the lowest: compounds 1, 2 and 3 (each within the scatter of the next, the first and the last beyond it).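

In this assay, within the data shown here, the exchange of chloro for methyl gives a 1.6-fold higher number from compound 2 to compound 3 (0.19 log units; within the scatter) and is the first measured exchange at this place on the shared core. On an aromatic carbon ortho to a fused ring and meta to a fused ring, the two groups therefore cannot be told apart on this read-out, and both compounds remain weak inhibitors of growth. No available evidence bears on this result.

On these data alone, whether another kind of group at this place, such as an amine, a methoxy group or a carboxylic acid, would give a step beyond the scatter remains open. Among these compounds, also open is whether chloro in place of methyl would read the same way on a core other than the one shared by compound 2 and compound 3.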